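The compounds below may be only part of what the source reports. "The series", "measured", "known", "first", "only" and "open" are said of these compounds alone.

Of the compounds shown here, three sharing one core have so far been tested in a functional assay on U-251 cells (Homo sapiens) for antiproliferative activity, read by MTT assay, with a stated time of 24 h (on this read-out higher numbers stand for weaker inhibition and lower numbers for stronger inhibition), and they differ only in the group on a saturated chain carbon bound to an oxygen on an aromatic ring. Compound 1 `C=CCOc1ccc2c(=O)c(-c3cc(OC)c(OC)cc3OC)coc2c1` carries vinyl there and gives 5900 nM. Compound 2 `C#CCOc1ccc2c(=O)c(-c3cc(OC)c(OC)cc3OC)coc2c1` carries ethynyl and gives 6450 nM. Compound 3 `COc1cc(OC)c(-c2coc3cc(OCc4ccc(Br)cc4)ccc3c2=O)cc1OC` carries 4-bromophenyl and gives 10000 nM, a value within the usual scatter of the other two.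

The next compound, compound 4 `COc1cc(OC)c(-c2coc3cc(OCc4ccccc4C#N)ccc3c2=O)cc1OC`, keeps the same core and places 2-cyanophenyl in place of 4-bromophenyl on a saturated chain carbon bound to an oxygen on an aromatic ring. For the measured compounds named here, no tested compound carries this group, so the evidence is indirect. The measured steps at this place are a 1.1-fold higher number from compound 1 to compound 2 (0.04 log units; within the scatter), a 1.7-fold higher number from compound 1 to compound 3 (0.23 log units; within the scatter) and a 1.6-fold higher number from compound 2 to compound 3 (0.19 log units; within the scatter). All three remain within the scatter, including the two that bring in a substituted phenyl group. On that basis, no step beyond the scatter is expected in this assay, and no direction can be firmly called. The expected change is a 1.3-fold lower number from compound 3 to compound 4 (0.12 log units; within the scatter). For compound 4, the estimated value is 7500 nM, with an expected range from 3500 nM to 15000 nM.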

Compound 4, half-maximal inhibitory concentration: 980 nM
Compound 4: the middle estimate sits 7.7-fold (0.88 log units) above what was measured; measured number below the stated range.
By their numbers in this assay, from the lowest: compound 4; then compounds 1, 2 and 3 (each within the scatter of the next).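

For the compounds shown here, the group on this saturated chain carbon can matter a great deal in this assay: 2-cyanophenyl in place of 4-bromophenyl gives a 10-fold lower number from compound 3 to compound 4 (1.01 log units; beyond the scatter), whereas the earlier steps at this place all stayed within the scatter. The gain is not confined to the comparison with a substituted phenyl group, as 2-cyanophenyl in place of ethynyl gives a 6.6-fold lower number from compound 2 to compound 4 (0.82 log units; beyond the scatter) and in place of vinyl gives a 6.0-fold lower number from compound 1 to compound 4 (0.78 log units; beyond the scatter), leaving compound 4 with the lowest number of the four, clearly apart from the other three. No available measurement explains this difference.

The change replaces bromine with a nitrile and also moves the substituent, from the 4 in the name 4-bromophenyl to the 2 in 2-cyanophenyl, so these compounds cannot show which of the two matters, or whether both are needed. An unsubstituted phenyl group would show what the bare ring gives at this place, while an amine or a carboxylic acid in place of the nitrile would test how specific the result is to that group.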